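Notes on an aryl exchange at the ethenyl chain

The compounds below may be only part of what the source reports. "The series", "measured", "known", "first", "only" and "open" are said of these compounds alone.

Measured in a functional assay on HeLa cells (Homo sapiens) for cytotoxicity, read by MTT assay, with a stated time of 72 h; a higher number here means a weaker inhibitor, a lower number a stronger inhibitor:
- compound 1 `O=C(/C=C/c1cc(Br)c(O)c(Br)c1)Nc1cc2c(Nc3ccc(F)c(Cl)c3)ncnc2cc1O[C@H]1CCOC1`: 27700 nM
- compound 2 `O=C(/C=C/c1ccc(F)cc1Cl)Nc1cc2c(Nc3ccc(F)c(Cl)c3)ncnc2cc1O[C@H]1CCOC1`: 37500 nM

Among the compounds with values here, only two numbers exist so far, and compound 2 is not separated from the other measured compound. Within the data shown here, the single measured step is a 1.4-fold higher number from compound 1 to compound 2 (0.13 log units; within the scatter).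

Compound 3 `COc1ccc(/C=C/C(=O)Nc2cc3c(Nc4ccc(F)c(Cl)c4)ncnc3cc2O[C@H]2CCOC2)cc1` keeps the shared core and has 4-methoxyphenyl in place of 2-chloro-4-fluorophenyl on a double-bonded chain carbon bound to a double-bonded chain carbon.

Among the measured compounds shown here, the one measured step at this place, the exchange of 3,5-dibromo-4-hydroxyphenyl for 2-chloro-4-fluorophenyl, bears directly on the change. For the measured compounds named here, no measured compound carries 4-methoxyphenyl, so this evidence is thin. Since that exchange gave only a 1.4-fold higher number from compound 1 to compound 2 (0.13 log units; within the scatter), no step beyond the scatter is expected in this assay, and neither direction is favoured.

The estimated change is small: a 1.2-fold lower number from compound 2 to compound 3 (0.07 log units; within the scatter).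

For compound 3 the expected value is 32000 nM, with an estimated range of 14000 nM to 70000 nM.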

Compound 3, half-maximal inhibitory concentration: 34600 nM
For compound 3 the middle estimate is 1.1-fold (0.03 log units) below the measured one; the range from low to high includes it.
By their numbers in this assay, from the lowest: compounds 1, 3 and 2 (each within the scatter of the next).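

In this assay, the step of a 1.1-fold lower number from compound 2 to compound 3 (0.03 log units; within the scatter) shows that an aryl group of carbon and oxygen only, with a hydrogen-bond acceptor, can stand on a double-bonded chain carbon bound to a double-bonded chain carbon without leaving the scatter, whereas both earlier groups carried halogen. The second comparison, a 1.2-fold higher number from compound 1 to compound 3 (0.10 log units; within the scatter), gives the same reading against 3,5-dibromo-4-hydroxyphenyl, so across compounds 1, 2 and 3 all three listed steps at this place lie within the scatter, and none of the three aryl groups is separated from the others. No measurement among the data shown accounts for this flat reading.

The compounds shown leave open whether a group of a different kind on this phenyl ring, such as an amine or a carboxylic acid, or a saturated alkyl chain in place of the aryl group, would give a step beyond the scatter. They also leave open whether the same flat reading would hold with a different group at any other place on the shared core.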